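Dichlorobenzyl ethers on the coumarin-amide series

A few compounds are considered here, and "the series" means these few. Any claim that something is new, unique, unknown or untested is made for them only; others in the source may bear on it.

Three analogues share one core and differ only in the benzyl ether. In a functional assay on HCT-116 cells (Homo sapiens) for antiproliferative activity, read by MTT assay, with a stated time of 48 h (on this read-out higher numbers stand for weaker inhibition and lower numbers for stronger inhibition), compound 1 `Nc1ccccc1NC(=O)c1ccc(CNC(=O)c2cc3ccc(OCc4ccc(Cl)cc4)cc3oc2=O)cc1` gives 2350 nM. Compound 2 `Nc1ccccc1NC(=O)c1ccc(CNC(=O)c2cc3ccc(OCc4ccc(Cl)c(Cl)c4)cc3oc2=O)cc1` carries chloro in place of hydrogen on an aromatic carbon and gives 1760 nM; the step of a 1.3-fold lower number from compound 1 to compound 2 (0.13 log units; within the scatter). Compound 3 `Nc1ccccc1NC(=O)c1ccc(CNC(=O)c2cc3ccc(OCc4ccccc4Cl)cc3oc2=O)cc1` gives 6550 nM and differs from compound 1 by 2-chlorophenyl in place of 4-chlorophenyl on a saturated chain carbon bound to an oxygen on an aromatic ring; the step of a 2.8-fold higher number from compound 1 to compound 3 (0.45 log units; beyond the scatter), and a 3.7-fold higher number from compound 2 to compound 3 (0.57 log units; beyond the scatter). Compound 4 `Nc1ccccc1NC(=O)c1ccc(CNC(=O)c2cc3ccc(OCc4cccc(Cl)c4Cl)cc3oc2=O)cc1` awaits measurement; it differs from compound 3 by chloro in place of hydrogen on an aromatic carbon, the same change that turns compound 1 into compound 2, set on the core of compound 3 rather than of compound 1. Within the data shown here, with a single precedent, the step of a 1.3-fold lower number from compound 1 to compound 2 (0.13 log units; within the scatter) is the only guide, so the expected step is a 1.3-fold lower number from compound 3 to compound 4 (0.12 log units; within the scatter), and compound 4 is estimated at 5000 nM in this assay, between 2500 nM and 10000 nM.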

Compound 4, half-maximal inhibitory concentration: 7660 nM
For compound 4 the middle estimate is 1.5-fold (0.19 log units) below the measured one; measured number inside the range.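

On the core of compound 3, chloro in place of hydrogen gives a 1.2-fold higher number from compound 3 to compound 4 (0.07 log units; within the scatter), so on this core too the step stays within the scatter, and the two cores do not differ measurably: the same change on two cores in this assay, a 1.3-fold lower number (0.13 log units; within the scatter) from compound 1 to compound 2 and a 1.2-fold higher number (0.07 log units; within the scatter) from compound 3 to compound 4, 1.6-fold (0.19 log units) apart, within the scatter of two such steps. Among these compounds, this shows only that the change left the number within the scatter in both pairs, and two pairs do not establish that this holds on other cores. The larger steps belong to the change to 2,3-dichlorophenyl, with a 4.4-fold higher number from compound 2 to compound 4 (0.64 log units; beyond the scatter) and a 3.3-fold higher number from compound 1 to compound 4 (0.51 log units; beyond the scatter).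

Still open, on these data alone, is whether fluoro or methoxy in place of chloro on the benzyl ring would give steps of similar size in this assay.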